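A few compounds are considered here, and "the series" means these few. Any claim that something is new, unique, unknown or untested is made for them only; others in the source may bear on it.

Measured compounds:
- compound 1: `Cc1ccc(-n2cc(CNC(=O)c3cccc4c3cnn4C(C)C)nn2)cc1C`
- compound 2: `CC(C)n1ncc2c(C(=O)NCc3cn(-c4ccccc4F)nn3)cccc21`
- compound 3: `CCc1ccc(-n2cc(CNC(=O)c3cccc4c3cnn4C(C)C)nn2)cc1`

In a functional assay on MCF7 cells (Homo sapiens) for inhibition, read by MTT assay, with a stated time of 72 h (a lower number here means a stronger inhibitor, a higher number a weaker inhibitor), compound 1 returns only a limit, > 40000 nM. In this assay compound 2 likewise returns only a limit, > 40000 nM. In this assay compound 3 also returns only a limit, > 40000 nM. All three values sit at the same limit (the limit of > 40000 nM in this assay, at which 3 of the 3 values shown sit), so compound 3 stands where the other two stand, with no number of its own. The steps a step that the two limits leave unreadable from compound 1 to compound 2, a step that the two limits leave unreadable from compound 1 to compound 3 and a step that the two limits leave unreadable from compound 2 to compound 3 therefore cannot be sized; changing the aryl group on the ring nitrogen among these three did not bring any of them into the readable range.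

The unmeasured compound 4 is `COc1ccc(Cn2cc(CNC(=O)c3cccc4c3cnn4C(C)C)nn2)cc1`; it differs from compound 3 by 4-methoxybenzyl in place of 4-ethylphenyl on an aromatic nitrogen. Going by the values given here, none of the measured steps swaps the group on that ring nitrogen from an aryl to a benzyl group, and none has a readable size, so nothing here points to a direction or size for the move from compound 3 to compound 4. Compound 4 is expected to remain at the limit as well, with the estimated step of a number no higher from compound 3 to compound 4 (the limit leaves the size open) carrying little weight. Compound 4 is estimated at 40000 nM, within 10000 nM to 100000 nM.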

Compound 4, half-maximal inhibitory concentration: > 40000 nM
Compound 4 ended at the assay's limit; the forecaster's own chance of this, stated with the estimate: 80%; the middle value sits exactly at the limit.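

In this assay compound 4 returns only a limit, > 40000 nM. Going by these compounds alone, no step linking it to compound 1, compound 2 or compound 3 can be read: the limit of > 40000 nM in this assay, at which 4 of the 4 values shown sit. The compounds shown leave open whether any group on that ring nitrogen brings the shared core into the readable range.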